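Varying the aryl group on the ring nitrogen toward compound 4

The source may hold more compounds than are shown below. What is called first, only, known or untested is meant among the compounds shown, and "the series" means these compounds.

In a functional assay on A549 cells (Homo sapiens) for antiproliferative activity, read by MTT assay, with a stated time of 48 h (on this read-out higher numbers stand for weaker inhibition and lower numbers for stronger inhibition), compound 3 `N#CC1=C(N)Oc2c(N)cc3nc4ccccc4nc3c2C12C(=O)N(Cc1cnnn1-c1ccc(F)c(Cl)c1)c1ccccc12` gives 43400 nM. Compound 2 `Cc1cc(C)cc(-n2nncc2CN2C(=O)C3(C(C#N)=C(N)Oc4c(N)cc5nc6ccccc6nc5c43)c3ccccc32)c1` gives 31200 nM in this assay, and the step of a 1.4-fold higher number from compound 2 to compound 3 (0.14 log units; within the scatter) is within the scatter, so the two numbers cannot be told apart. Compound 1 `COc1ccc(-n2nncc2CN2C(=O)C3(C(C#N)=C(N)Oc4c(N)cc5nc6ccccc6nc5c43)c3ccccc32)cc1` returns only a limit of > 50000 nM in this assay. Because compound 1 sits at the limit of > 50000 nM in this assay, at which 1 of the 3 values shown sits, the steps of an at least 1.1-fold lower number from compound 1 to compound 3 (0.06 log units; that floor lies within the scatter) and an at least 1.6-fold lower number from compound 1 to compound 2 (0.20 log units; that floor lies within the scatter) are known only as floors, and both floors lie within the scatter. Compound 4 `COc1cc(-n2nncc2CN2C(=O)C3(C(C#N)=C(N)Oc4c(N)cc5nc6ccccc6nc5c43)c3ccccc32)c(OC)cc1Cl` has not been measured; it differs from compound 3 by 4-chloro-2,5-dimethoxyphenyl in place of 3-chloro-4-fluorophenyl on an aromatic nitrogen. Every measured step exchanges the aryl group on that same aromatic nitrogen, and none of them moved the number beyond the scatter, so no step beyond the scatter is expected for compound 4 in this assay. Compound 4 is therefore estimated at 45000 nM, between 22000 nM and 100000 nM, the step of a 1.0-fold higher number from compound 3 to compound 4 (0.02 log units; within the scatter) being expected to stay within the scatter. Given that compound 1 reached only a limit, a limit is also a real possibility for compound 4.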

Compound 4, half-maximal inhibitory concentration: > 50000 nM
Compound 4: only a limit was reported; the forecaster's own chance of this, stated with the estimate: 35%; middle value at least 1.1-fold (0.04 log units) away from the limit.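

On the aromatic nitrogen, 4-chloro-2,5-dimethoxyphenyl brings hydrogen-bond acceptors that 3-chloro-4-fluorophenyl lacks, yet the readable steps show no gain: an at least 1.1-fold higher number from compound 3 to compound 4 (0.06 log units; that floor lies within the scatter) and an at least 1.6-fold higher number from compound 2 to compound 4 (0.20 log units; that floor lies within the scatter) are both only floors within the scatter, so neither establishes a real loss. The step between compound 1 and compound 4 cannot be read. In this assay compound 4 is a second compound on this nitrogen to reach a limit rather than a number: the limit of > 50000 nM in this assay, at which 2 of the 4 values shown sit.

On these data alone, all four compounds carry a substituted phenyl on this nitrogen, so the effect of a pyridyl ring, a benzyl group or a simple alkyl chain there remains open. As far as these compounds go, it is also open whether an amine or a carboxylic acid on the aryl ring would move the number beyond the scatter.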